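This account rests on a few compounds, and the source may have more. Where it says the series, first, only, none or still open, it means among the compounds named here.

Compound 3 `CC(C)CCn1nc(-c2cncs2)c(O)c(C2=NS(=O)(=O)c3cc(NS(C)(=O)=O)ccc3N2)c1=O` is one of three compounds placed into an ADME assay on Huh-7 cells (Homo sapiens) for cytotoxicity, with a stated time of 72 h; a lower number here means that less compound is tolerated, a higher number that more compound is tolerated. For compound 3 the result is only a limit of the assay, > 33000 nM. Compound 1 `COCN(c1ccc2c(c1)S(=O)(=O)N=C(c1c(O)c(-c3cccs3)nn(CCC(C)C)c1=O)N2)S(C)(=O)=O` likewise gives only a limit, > 1000 nM. Compound 2 `CC(C)CCn1nc(-c2cccs2)c(O)c(C2=NS(=O)(=O)c3cc(S(C)(=O)=O)ccc3N2)c1=O` has no result in this assay, its entry reading "not determined" (no result reported). Going by the values given here, compound 3 therefore stands among two limits and one missing entry, with no single number to set against it, and no step between measured compounds can be drawn. Compound 4 `CC(C)CCc1nn(CCC(C)C)c(=O)c(C2=NS(=O)(=O)c3cc(NS(C)(=O)=O)ccc3N2)c1O` differs from compound 3 in one place: isopentyl in place of 1,3-thiazol-5-yl on an aromatic carbon. With nothing measured to lean on, the expected step is none beyond the usual scatter, a number no higher from compound 3 to compound 4 (the limit leaves the size open), and most likely again only a limit. Compound 4 is estimated at 33000 nM, with a range from 10000 nM to 100000 nM.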

Compound 4, half-maximal cytotoxic concentration: > 33000 nM
Compound 4 was reported as a limit (the forecaster's own chance of this, stated with the estimate: 80%); the middle value lies on the limit itself.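

Compound 3 and compound 4 are both reported only as limits, and the step between them cannot be read. The compounds shown leave open whether isopentyl in place of 1,3-thiazol-5-yl shifts the tolerated concentration in this assay at all.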